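Swapping Chloro for Bromo in a Weakly Cytotoxic Series

A few compounds are considered here, and "the series" means these few. Any claim that something is new, unique, unknown or untested is made for them only; others in the source may bear on it.

Measured compounds:
compound 1 `Nc1nc(-c2ccccc2)cn1/N=C/c1cc2ccccc2nc1Cl`: 49000 nM
compound 2 `Cc1ccc(-c2cn(/N=C/c3cc4ccccc4nc3Cl)c(N)n2)cc1`: > 50000 nM
compound 3 `Nc1nc(-c2ccc(Cl)cc2)cn1/N=C/c1cc2ccccc2nc1Cl`: > 50000 nM

In a functional assay on MDA-MB-231 cells (Homo sapiens) for cytotoxicity, read by MTT assay, with a stated time of 48 h (a lower number here means a stronger inhibitor, a higher number a weaker inhibitor), compound 1 gives 49000 nM. For compound 2 the value > 50000 nM is a limit of the assay rather than a number. For compound 3 the value > 50000 nM is likewise a limit. Compound 3 therefore stands at the edge of what this assay can report, as the limit of > 50000 nM in this assay, at which 2 of the 3 values shown sit, makes plain.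

Compound 4 `Nc1nc(-c2ccc(Br)cc2)cn1/N=C/c1cc2ccccc2nc1Cl` differs from compound 3 by one change: bromo in place of chloro on an aromatic carbon. Within the data shown here, two measured steps touch the same position of the shared core. The step of an at least 1.0-fold higher number from compound 1 to compound 3 (0.00 log units; that floor lies within the scatter) reached only a floor, and the step that the two limits leave unreadable from compound 2 to compound 3 could not be sized at all. Nothing measured shows this position moving the read-out of this assay beyond the scatter.

Compound 4 is therefore expected to sit, like compound 3, at or beyond the limit of this assay, with an estimated step that the limit leaves unreadable from compound 3 to compound 4. The estimate for compound 4 is 70000 nM, in the range 30000 nM to 200000 nM.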

Compound 4, half-maximal inhibitory concentration: > 50000 nM
Compound 4: a limit, no number; the forecaster's own chance of this, stated with the estimate: 75%; the middle value does not contradict the limit.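

Like methyl and chloro, bromo at this position leaves only a limit and not a number, so the change from 4-chlorophenyl to 4-bromophenyl adds one more compound at the edge of this assay: the limit of > 50000 nM in this assay, at which 3 of the 4 values shown sit.

Among these compounds, the one comparison with a readable floor is an at least 1.0-fold higher number from compound 1 to compound 4 (0.00 log units; that floor lies within the scatter). The steps to compound 4 from compound 2 and from compound 3 cannot be read, so even with a third substituent, nothing shown moves the read-out at this position beyond the scatter.

As far as these compounds go, how an amine or a carboxylic acid in place of the bromo would read remains open. So does the question of whether any group here can bring a compound clearly inside the range of this assay, where a real difference could be sized.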